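Bromophenyl swap on the hydroxyethoxy compound

The source may report more compounds than this note shows. Statements on the series, on what has been measured and on what is new or still open speak of the compounds shown alone.

Values in a functional assay on SK-MEL-28 cells (Homo sapiens) for cytotoxicity, read by CCK-8 assay, with a stated time of 24 h (a lower number here means a stronger inhibitor, a higher number a weaker inhibitor), are as follows
compound 1 `COc1ccccc1Oc1c(N)nc(-c2ccc(Br)cc2)nc1Cl` gives 14 nM
compound 2 `COc1ccccc1Oc1c(N)nc(-c2cccc(F)c2)nc1OCCO` gives 3210 nM

Of the two numbers in this assay the higher belongs to compound 2 (3210 nM), and the gap to compound 1 (14 nM) lies beyond the scatter. Compound 3 `COc1ccccc1Oc1c(N)nc(-c2ccc(Br)cc2)nc1OCCO` keeps the 2-hydroxyethoxy group of compound 2 and carries 4-bromophenyl in place of 3-fluorophenyl (4-bromophenyl in place of 3-fluorophenyl on an aromatic carbon) on an aromatic carbon between two ring nitrogen atoms.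

The expectation rests on compound 1, which carries the same 4-bromophenyl and gives 14 nM in this assay but lacks the 2-hydroxyethoxy group. Compound 1 and compound 2 differ in two places, and the data do not show how much of their gap belongs to either place. Only part of that gap is therefore expected to carry over. An estimated 16-fold lower number from compound 2 to compound 3 (1.21 log units; beyond the scatter) is expected in this assay and would lie beyond the scatter. For compound 3 the estimated value is 200 nM (expected range 25 nM to 1600 nM).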

Compound 3, half-maximal inhibitory concentration: 4400 nM
Compound 3: the middle estimate sits 22-fold (1.34 log units) below what was measured, outside the stated range (above it).
By their numbers in this assay, from the lowest: compound 1; then compounds 2 and 3 (each within the scatter of the next).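

In this assay, 4-bromophenyl in place of 3-fluorophenyl on the aromatic carbon between two ring nitrogen atoms gives a 1.4-fold higher number from compound 2 to compound 3 (0.14 log units; within the scatter) and so does not move the read-out beyond the scatter while the 2-hydroxyethoxy group is present. With 4-bromophenyl held constant, 2-hydroxyethoxy in place of chloro gives a 310-fold higher number from compound 1 to compound 3 (2.50 log units; beyond the scatter), a large step that places the change in this pair at the chloro position rather than at the aryl position. No measurement at hand bears on the reason for either step.

Open, from the compounds shown here alone, is whether chloro itself is needed for the low number of compound 1 in this assay, or whether other small groups at that place, such as a methoxy group, an amine or a carboxylic acid, or a longer chain ending in hydroxyl, would read closer to compound 1 or to compound 3. Also open, going by these compounds, is whether 3-fluorophenyl and 4-bromophenyl would remain within the scatter of each other with chloro at that place, as the aryl swap can be read here only alongside 2-hydroxyethoxy.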